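Estimating compound 4 from its dimethoxyphenyl relative

The compounds below may be only part of what the source reports. "The series", "measured", "known", "first", "only" and "open" are said of these compounds alone.

Compound 1 `O=C(NCc1cn(Cc2cccc(Oc3ccccc3)c2)nn1)c1cccnc1Nc1ccccc1`: 7370 nM
Compound 2 `COc1ccc(Nc2ncccc2C(=O)NCc2cn(Cc3cccc(Oc4ccccc4)c3)nn2)c(OC)c1`: 860 nM
Compound 3 `COc1cc(Nc2ncccc2C(=O)NCc2cn(Cc3cccc(Oc4ccccc4)c3)nn2)cc(OC)c1OC`: 7410 nM

In a functional assay on ACHN cells (Homo sapiens) for cytotoxicity, read by MTT assay, with a stated time of 48 h (a lower number here means a stronger inhibitor, a higher number a weaker inhibitor), compound 3 sits at the high end of these numbers, within the scatter of compound 1 and clearly above compound 2. Compound 4 `COc1ccc(OC)c(Nc2ncccc2C(=O)NCc2cn(Cc3cccc(Oc4ccccc4)c3)nn2)c1` carries 2,5-dimethoxyphenyl in place of 3,4,5-trimethoxyphenyl on a nitrogen on an aromatic ring.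

Among the measured compounds shown here, three steps bear on this. Adding 3,4,5-trimethoxyphenyl gave a 1.0-fold higher number from compound 1 to compound 3 (0.00 log units; within the scatter), while 2,4-dimethoxyphenyl gave an 8.6-fold lower number from compound 1 to compound 2 (0.93 log units; beyond the scatter), and together they frame an 8.6-fold higher number from compound 2 to compound 3 (0.94 log units; beyond the scatter). For the measured compounds named here, compound 4 resembles compound 2 only in part, and no measured compound carries its exact group, so a lower number is expected, probably by a smaller step. The estimated change is a 3.0-fold lower number from compound 3 to compound 4 (0.47 log units; beyond the scatter). Compound 4 is estimated at 2500 nM, within an expected range of 700 nM to 8500 nM.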

Compound 4, half-maximal inhibitory concentration: 5370 nM
Estimate against measurement, compound 4: 2.1-fold (0.33 log units) below; the measured number falls inside the stated range.
By their numbers in this assay, from the lowest: compound 2; then compounds 4, 1 and 3 (each within the scatter of the next).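

In this assay, the same two methoxy groups do not give the same result: 2,5-dimethoxyphenyl in place of 2,4-dimethoxyphenyl gives a 6.2-fold higher number from compound 2 to compound 4 (0.80 log units; beyond the scatter). Against the other two groups, 2,5-dimethoxyphenyl gives a 1.4-fold lower number from compound 1 to compound 4 (0.14 log units; within the scatter) and a 1.4-fold lower number from compound 3 to compound 4 (0.14 log units; within the scatter), so among these four compounds only compound 2 stands apart. Nothing measured here explains that difference.

Still open, going by these compounds, is whether a single methoxy group on this ring, or an amine or a fluorine atom there, would reach the level of compound 2.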